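The source may hold more compounds than are shown below. What is called first, only, known or untested is meant among the compounds shown, and "the series" means these compounds.

Three compounds share one core and differ only in a group on the aromatic ring. Compound 1 `OC[C@@]1(c2ccc(O)cc2)NC[C@@H](O)[C@@H]1O` carries a hydroxy there, compound 2 `COc1cccc([C@]2(CO)NC[C@@H](O)[C@@H]2O)c1` a methoxy, and compound 3 `Cc1ccc([C@]2(CO)NC[C@@H](O)[C@@H]2O)cc1` a methyl. In an assay on isolated protein for inhibition of alpha-mannosidase (Canavalia ensiformis), tested at 1000 uM (on this read-out lower numbers stand for less inhibition and higher numbers for more inhibition at the one concentration tested (going by the name of the read-out)), compound 1 gives 2.2%, compound 2 gives 0% and compound 3 gives 0%; compound 3 shows the same number as compound 2, and all three values lie within the usual scatter of one another. Among the compounds with values here, the single measured step at this position, a number 2.2 percentage points lower from compound 1 to compound 3 (within the scatter), stays within the scatter. Compound 4 `OC[C@@]1(c2ccccc2)NC[C@@H](O)[C@@H]1O` differs from compound 3 by hydrogen in place of methyl on an aromatic carbon. Within the data shown here, no measured step removes a methyl, so the expected step of a number 1 percentage points higher from compound 3 to compound 4 (within the scatter) is none beyond the scatter, and compound 4 is estimated at 1%, between 0% and 10%.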

Compound 4, a percentage reported as inhibition, at one concentration (the size of the read-out at that concentration, not a potency): 0%
For compound 4 the middle estimate is 1 percentage points above the measured one; measured number inside the range.
By their numbers in this assay, from the lowest: compounds 2, 3, 4 and 1 (each within the scatter of the next).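

With plain hydrogen on the ring, this position can now be read against having no group there at all: in this assay, replacing the methyl (no change at the digits printed from compound 3 to compound 4 (within the scatter)), the methoxy (no change at the digits printed from compound 2 to compound 4 (within the scatter)) or the hydroxy (a number 2.2 percentage points lower from compound 1 to compound 4 (within the scatter)) with hydrogen stays within the scatter. None of these three groups is therefore shown to matter here. Nothing available explains this result. From the compounds shown here alone, whether an amine, a carboxylic acid or a longer chain on this ring would move the number beyond the scatter remains open.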